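A few compounds are considered here, and "the series" means these few. Any claim that something is new, unique, unknown or untested is made for them only; others in the source may bear on it.

Values in a functional assay on HeLa cells (Homo sapiens) for inhibition, with a stated time of 72 h (a lower number here means a stronger inhibitor, a higher number a weaker inhibitor), so far:
- Compound 1 (`COC(=O)C[C@H](NC(=O)OC(C)(C)C)C(=O)N(Cc1ccccc1)C1(C(=O)NCc2ccccc2)CCN(Cc2ccccc2)CC1`) gives 20000 nM here.
- Compound 2 (`COC(=O)C[C@H](NC(=O)OC(C)(C)C)C(=O)N(Cc1ccccc1)C1(C(=O)NCc2ccccc2)CCN(C(=O)OC(C)(C)C)CC1`) gives 24000 nM here.
- Compound 3 (`CCCCNC(=O)C1(N(Cc2ccccc2)C(=O)[C@H](CC(=O)OC)NC(=O)OC(C)(C)C)CCN(Cc2ccccc2)CC1`) gives 36000 nM here.

Compound 3 stands within the scatter of both compound 1 and compound 2, so these three values do not separate the compounds in this assay at all.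

Compound 4 (`COC(=O)C[C@H](NC(=O)OC(C)(C)C)C(=O)N(Cc1ccccc1)C1(C(=O)NC(C)(C)C)CCN(Cc2ccccc2)CC1`) is the next entry in the series. It carries tert-butyl in place of butyl on an amide-type nitrogen. Within the data shown here, no measured pair makes this exact swap, so the evidence is indirect.

The closest measured step also alters the group on that amide-type nitrogen, with propyl in place of phenyl on the saturated chain carbon bound to it (a 1.8-fold higher number from compound 1 to compound 3 (0.26 log units; within the scatter)). That step stays within the scatter. The other step, with tert-butoxycarbonyl in place of benzyl on an amine nitrogen in a ring (a 1.2-fold higher number from compound 1 to compound 2 (0.08 log units; within the scatter)), stays within the scatter too.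

With both steps this small, no change beyond the scatter is expected in this assay, and no direction can be argued. The expected step is small (a 1.2-fold lower number from compound 3 to compound 4 (0.08 log units; within the scatter)). For compound 4 the estimated value is 30000 nM, with an expected range from 14000 nM to 60000 nM as the working bracket.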

Compound 4, half-maximal inhibitory concentration: 21000 nM
For compound 4 the middle estimate is 1.4-fold (0.15 log units) above the measured one; low and high end bracket the measured number.
By their numbers in this assay, from the lowest: compounds 1, 4, 2 and 3 (each within the scatter of the next).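

In this assay, tert-butyl in place of butyl on the amide-type nitrogen gives a 1.7-fold lower number from compound 3 to compound 4 (0.23 log units; within the scatter), and tert-butyl in place of benzyl at the same nitrogen gives a 1.1-fold higher number from compound 1 to compound 4 (0.02 log units; within the scatter). Among these compounds, the series now holds three different groups at this place on the shared core (benzyl in compound 1, butyl in compound 3, tert-butyl in compound 4), and no step among them leaves the scatter. Butyl and tert-butyl have the same heavy-atom count and differ only in how those atoms are joined, and that rearrangement does not separate compound 3 from compound 4 in this read-out, though no measurement here accounts for the closeness of these values.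

Still open, as far as these compounds go, is whether any group on this amide-type nitrogen can move the value beyond the scatter in this assay, for example a much longer chain or a chain ending in an amine. Also open is whether a carboxylic acid in place of the methyl ester, a change away from this nitrogen, would separate from the compounds shown.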